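A few compounds are considered here, and "the series" means these few. Any claim that something is new, unique, unknown or untested is made for them only; others in the source may bear on it.

Working notes on the series

The shared core is seen in compound 1 `Oc1ccc(-c2cc(-c3cccs3)cc(-c3ccccc3O)n2)cc1`. In a functional assay on HCT-15 cells (Homo sapiens) for cytotoxicity, read by CCK-8 assay (on this read-out lower numbers stand for stronger inhibition and higher numbers for weaker inhibition), compound 1 stands at the limit of the assay, reported as > 50000 nM. Compound 2 `Oc1ccc(-c2cc(-c3cccs3)cc(-c3cccc(O)c3)n2)cc1` carries 3-hydroxyphenyl where compound 1 carries 2-hydroxyphenyl; in this assay compound 2 gives 1770 nM. Compound 3 `Oc1ccc(-c2cc(-c3ccsc3)cc(-c3ccccc3O)n2)cc1` carries thiophen-3-yl where compound 1 carries thiophen-2-yl. In this assay compound 3 also stands at the limit, reported as > 50000 nM. The step that the two limits leave unreadable from compound 1 to compound 3 cannot be sized, since (the limit of > 50000 nM in this assay, at which 2 of the 3 values shown sit); nothing can be said on whether compound 1 and compound 3 differ.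

Compound 4 `Oc1ccc(-c2cc(-c3ccsc3)cc(-c3cccc(O)c3)n2)cc1` is not yet measured. It differs from compound 3 by 3-hydroxyphenyl in place of 2-hydroxyphenyl on an aromatic carbon. Within the data shown here, the one measured step of this kind is an at least 28-fold lower number from compound 1 to compound 2 (1.45 log units; beyond the scatter), which left the limit behind and reached a clear number. Compound 4 is therefore expected to follow that step and come down from the limit of compound 3 by a large amount; the expected step is an at least 20-fold lower number from compound 3 to compound 4 (1.30 log units; beyond the scatter). On these data alone, whether the thiophen-3-yl group alters this is unknown, as compound 3 gives only a limit. The estimate for compound 4 in this assay is 2500 nM, expected within 500 nM to 25000 nM.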

Compound 4, half-maximal inhibitory concentration: 1180 nM
Compound 4: middle estimate off by 2.1-fold (0.33 log units), on the high side; low and high end bracket the measured number.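

On the thiophen-3-yl core as well, 3-hydroxyphenyl in place of 2-hydroxyphenyl next to the ring nitrogen brings the series off the limit in this assay, giving an at least 42-fold lower number from compound 3 to compound 4 (1.62 log units; beyond the scatter). The change therefore holds on both cores shown, though the sizes of its two steps cannot be compared: the same change on two cores in this assay, an at least 28-fold lower number (1.45 log units; beyond the scatter) from compound 1 to compound 2 and an at least 42-fold lower number (1.62 log units; beyond the scatter) from compound 3 to compound 4; the limit leaves it open whether they differ With 3-hydroxyphenyl in place, thiophen-3-yl and thiophen-2-yl can now be compared, and a 1.5-fold lower number from compound 2 to compound 4 (0.18 log units; within the scatter) does not tell them apart, whereas the step between the two 2-hydroxyphenyl compounds cannot be read.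

Still open, on these data alone, is whether the hydroxyl of 3-hydroxyphenyl is needed at all: a plain phenyl, a 3-methoxyphenyl or a 3-aminophenyl at this position would test that, and a 4-hydroxyphenyl there would complete the placements of the hydroxyl. The true size of the step also stays open, with both 2-hydroxyphenyl compounds held at a limit: the limit of > 50000 nM in this assay, at which 2 of the 4 values shown sit.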